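Replacing Propyl with Trimethoxyphenyl: What to Expect

The source may hold more compounds than are shown below. What is called first, only, known or untested is meant among the compounds shown, and "the series" means these compounds.

Of the compounds shown here, three sharing one core have been tested so far in a functional assay on HepG2 cells (Homo sapiens) for cytotoxicity, read by MTT assay, with a stated time of 48 h; on this read-out lower numbers stand for stronger inhibition and higher numbers for weaker inhibition. Compound 1 `CCCc1nnc(SCc2ccccc2)n1N1C(=O)c2ccccc2C1=O` sits at the limit of the assay, giving > 200000 nM, which is a limit and not a number. Compound 2 `CCCc1nnc(SCC(=O)c2ccc(Cl)cc2)n1N1C(=O)c2ccccc2C1=O` likewise gives only a limit, > 200000 nM. Compound 3 `CCCc1nnc(SCC(=O)c2ccccc2)n1N1C(=O)c2ccccc2C1=O` also gives only a limit, > 200000 nM. Compound 3 therefore stands nowhere distinct on the numbers shown: all three values sit at the limit of > 200000 nM in this assay, at which 3 of the 3 values shown sit, so none can be called more or less active than another.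

The step now followed leads to compound 4 `COc1cc(-c2nnc(SCC(=O)c3ccccc3)n2N2C(=O)c3ccccc3C2=O)cc(OC)c1OC`. The change is 3,4,5-trimethoxyphenyl in place of propyl on an aromatic carbon, in words 3,4,5-trimethoxyphenyl in place of propyl on an aromatic carbon, the one that lies between two ring nitrogen atoms. The measured steps are a step that the two limits leave unreadable from compound 1 to compound 2, a step that the two limits leave unreadable from compound 1 to compound 3 and a step that the two limits leave unreadable from compound 2 to compound 3; each is unreadable because both ends rest at the limit of > 200000 nM in this assay, at which 3 of the 3 values shown sit, so they carry no size. Among the measured compounds shown here, none of them touches the aromatic carbon changed here, and no measured step of any readable size bears on the present change.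

Compound 4 is therefore expected at 150000 nM, within 20000 nM to 300000 nM, an expected step of an at least 1.3-fold lower number from compound 3 to compound 4 (0.12 log units; that floor lies within the scatter) in this assay, with the limit remaining the most likely report.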

Compound 4, half-maximal inhibitory concentration: 171000 nM
The estimate for compound 4 lay 1.1-fold (0.06 log units) below the measured number, within the range that was stated.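

In this assay, placing 3,4,5-trimethoxyphenyl in place of propyl on the aromatic carbon between two ring nitrogen atoms gives the only reading among the compounds shown that is a number and not a limit, whereas the steps among compound 1, compound 2 and compound 3, which all alter the group on the sulfur, cannot be read. The change brings in a much larger group with an aromatic ring and hydrogen-bond acceptors, and what can be read of it is an at least 1.1-fold lower number from compound 3 to compound 4 (0.06 log units; that floor lies within the scatter). The result gives only this floor, and the true size of the step stays unknown, because the starting point is a limit and not a number: the limit of > 200000 nM in this assay, at which 3 of the 4 values shown sit.

The compounds shown leave open whether the reading depends on the three methoxy groups or on the aromatic ring alone, which an unsubstituted phenyl or a single methoxyphenyl at this carbon would help to separate. They also leave open whether the same change would give a measurable number with the benzyl group of compound 1 or the 4-chlorobenzoyl group of compound 2 on the sulfur.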